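A few compounds are considered here, and "the series" means these few. Any claim that something is new, unique, unknown or untested is made for them only; others in the source may bear on it.

Working notes on the series. In a functional assay on the whole organism (strain Wistar) for inhibition, with Rattus norvegicus as the target, read by paw edema, with stated times of 30 min and 2 h, at a dose of 20 mg/kg (a lower number here means less inhibition, a higher number more inhibition at the dose given (going by the name of the read-out)), compound 1 `CCOC(=O)C1=C(C)NC(C)=C(C(=O)OCC)C1c1ccc(OCC(=O)NCc2ccccc2)cc1` gives 8.9%, the lowest of the three numbers in hand. Compound 2 `CCOC(=O)C1=C(C)NC(C)=C(C(=O)OCC)C1c1ccc(OCC(=O)Nc2ccc(C)cc2)cc1` gives 62.2% in this assay and compound 3 `CCOC(=O)C1=C(C)NC(C)=C(C(=O)OCC)C1c1ccc(OCC(=O)Nc2nc3ccccc3s2)cc1` gives 64.5%. Both measured steps away from compound 1 are large and upward: a number 53.3 percentage points higher from compound 1 to compound 2 (beyond the scatter) and a number 55.6 percentage points higher from compound 1 to compound 3 (beyond the scatter), whereas a number 2.3 percentage points higher from compound 2 to compound 3 (within the scatter).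

The step to compound 4 `CCOC(=O)C1=C(C)NC(C)=C(C(=O)OCC)C1c1ccc(OCc2nnc(S)o2)cc1` is of a different kind. 5-sulfanyl-1,3,4-oxadiazol-2-yl in place of benzylcarbamoyl on a saturated chain carbon bound to an oxygen on an aromatic ring The measured steps from compound 1 each kept the amide and changed only the group on its nitrogen; here the whole benzylcarbamoyl is gone and a 5-sulfanyl-1,3,4-oxadiazol-2-yl stands on the saturated chain carbon bound to the oxygen on the aromatic ring instead. Going by the values given here, no measured pair in this set bears directly on such a change, so the two large upward steps from compound 1 only show that its low number is sensitive to what sits beyond the ether oxygen, not which way a heteroaryl without the amide will move it.

Compound 4 is therefore expected to land in this assay at 35%, within 5% to 65%, which is an estimated step of a number 26.1 percentage points higher from compound 1 to compound 4 (beyond the scatter) with wide uncertainty.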

Compound 4, a percentage reported as inhibition, in the whole organism at one dose (the size of the read-out at that dose, not a potency): 61.7%
The estimate for compound 4 lay 26.7 percentage points below the measured number; low and high end bracket the measured number.
By their numbers in this assay, from the lowest: compound 1; then compounds 4, 2 and 3 (each within the scatter of the next).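

The group beyond the saturated chain carbon bound to an oxygen on an aromatic ring need not be an amide to give a high number in this assay: with the benzylcarbamoyl gone altogether, the change shows a number 52.8 percentage points higher from compound 1 to compound 4 (beyond the scatter). Compared with the two amides that gave high numbers, the same position shows a number 0.5 percentage points lower from compound 2 to compound 4 (within the scatter) and a number 2.8 percentage points lower from compound 3 to compound 4 (within the scatter), so the 5-sulfanyl-1,3,4-oxadiazol-2-yl, (4-methylphenyl)carbamoyl and (1,3-benzothiazol-2-yl)carbamoyl groups cannot be told apart here, and among these four compounds only the benzylcarbamoyl of compound 1 stands apart. Nothing at hand accounts for this shared level or for the low number of compound 1.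

As far as these compounds go, it remains open whether the sulfanyl group contributes to the number of compound 4, which an amino or methyl group in its place on the oxadiazole would test. Also open, from the compounds shown here alone, is whether the low number of compound 1 is particular to benzyl on the amide nitrogen, which an unsubstituted phenyl or a longer chain such as 2-phenylethyl there would help to decide.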